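The source may report more compounds than this note shows. Statements on the series, on what has been measured and on what is new or still open speak of the compounds shown alone.

Compound 1 `CN(C(=O)c1ccccc1)c1ccc2[nH]c(-c3n[nH]c4ccccc34)cc2n1` carries a benzoyl group on the methylated nitrogen of the shared core, and in a functional assay on KB cells (Homo sapiens) for antiproliferative activity, read by MTT assay, with a stated time of 72 h (a higher number here means a weaker inhibitor, a lower number a stronger inhibitor), compound 1 gives 8580 nM. Compound 2 `CN(c1ccc2[nH]c(-c3n[nH]c4ccccc34)cc2n1)S(=O)(=O)c1ccccc1` keeps that core and replaces the benzoyl with a phenylsulfonyl; in this assay compound 2 gives 2400 nM. Going by the values given here, the single step measured so far, a 3.6-fold lower number from compound 1 to compound 2 (0.55 log units; beyond the scatter), is the only change recorded, and it shows that the sulfonyl-bearing compound 2 holds the lower of the two numbers, with compound 1 the nearest neighbour at a higher value.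

Compound 3 `COc1ccc(OC)c(S(=O)(=O)N(C)c2ccc3[nH]c(-c4n[nH]c5ccccc45)cc3n2)c1` differs from compound 2 by 2,5-dimethoxyphenyl in place of phenyl on a sulfonyl sulfur. Among the compounds with values here, no measured pair speaks to substituents on the aryl ring of the sulfonyl: the step from compound 1 to compound 2 concerns the group attached to the nitrogen, not the ring on the sulfur, and so it bears on this change only in telling what a phenylsulfonyl itself gives. With nothing to suggest a direction, the change from compound 2 to compound 3 is expected to amount to a 1.2-fold lower number from compound 2 to compound 3 (0.08 log units; within the scatter), a step not clearly beyond the scatter. Compound 3 is therefore estimated at 2000 nM in this assay, within a range from 700 nM to 6000 nM.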

Compound 3, half-maximal inhibitory concentration: 4380 nM
Compound 3: middle estimate off by 2.2-fold (0.34 log units), on the low side, and the stated range covers the measured number.
By their numbers in this assay, from the lowest: compounds 2, 3 and 1 (each within the scatter of the next, the first and the last beyond it).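

On a sulfonyl sulfur whose other neighbour is the sulfonamide nitrogen, putting 2,5-dimethoxyphenyl in place of phenyl comes to a 1.8-fold higher number from compound 2 to compound 3 (0.26 log units; within the scatter) in this assay, so compound 2 and compound 3 cannot be told apart in this measurement. Going by these compounds alone, this is the first reading on the aryl ring of the sulfonyl, since the earlier step concerned only the group attached to the nitrogen, and it shows that this ring can carry the 2,5-dimethoxyphenyl pattern without the number moving beyond the scatter. Nothing available here offers an explanation for this result.

The compounds shown leave open whether a single methoxy group on the phenyl would behave as the 2,5-dimethoxyphenyl does, since the two methoxy groups enter together and their contributions cannot be separated. They also leave open whether quite different groups on that ring, such as an amine, a carboxylic acid or a fluorine, would shift the number beyond the scatter in either direction.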